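Swapping Azetidin-1-yl for (tert-Butyl)amino

The source may hold more compounds than are shown below. What is called first, only, known or untested is meant among the compounds shown, and "the series" means these compounds.

Compound 2 `c1nc(N2CCC2)c2ncn(CC3CC3)c2n1`: 30%
Compound 1 `CC(=O)Nc1ccc(Cn2cnc3c(N(C)C)ncnc32)cc1`: 0%

Both compounds were tested in a functional assay on the whole organism for inhibition, with Rattus norvegicus as the target, at a dose of 25 mg/kg by the intraperitoneal route; a lower number here means less inhibition, a higher number more inhibition at the dose given (going by the name of the read-out). In this assay compound 2 gives 30%, the highest of the two numbers, while compound 1 gives 0%, a gap beyond the usual scatter. Compound 3 `CC(C)(C)Nc1ncnc2c1ncn2CC1CC1` awaits measurement. Its difference from compound 2 is (tert-butyl)amino in place of azetidin-1-yl on an aromatic carbon. For the measured compounds named here, no step between measured compounds shows what such an exchange does, so the expectation rests on compound 2 alone. The step of no change at the digits printed from compound 2 to compound 3 (within the scatter) is expected to be small, in either direction or none beyond the scatter. Compound 3 is therefore estimated to give about 30%, between 5% and 55%.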

Compound 3, a percentage reported as inhibition, in the whole organism at one dose (the size of the read-out at that dose, not a potency): 0%
For compound 3 the middle estimate is 30 percentage points above the measured one, and the stated range ends above it.
By their numbers in this assay, from the lowest: compounds 1 and 3 (each within the scatter of the next); then compound 2.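

In this assay the exchange of azetidin-1-yl for (tert-butyl)amino on this aromatic carbon gives a number 30 percentage points lower from compound 2 to compound 3 (beyond the scatter), so the position does not treat these two amine groups alike. The exchange removes a four-membered ring and brings in a hydrogen-bond donor, and this single step cannot separate those two differences. Nothing measured here gives a cause for the step. Still open, going by these compounds, is whether pyrrolidin-1-yl at this carbon would keep the inhibition. An open-chain n-butylamino group in the same place would add a further comparison with (tert-butyl)amino.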